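A few compounds are considered here, and "the series" means these few. Any claim that something is new, unique, unknown or untested is made for them only; others in the source may bear on it.

Measured so far:
compound 1, `COc1ccc(C2=NN(c3ccccc3)C(c3ccc(C)cc3)C2S(=O)(=O)CC2=NCCO2)cc1`: 62.5%
compound 2, `COc1ccc(C2=NN(c3ccccc3)C(c3ccc(C)cc3)C2S(=O)(=O)CC2=NCCS2)cc1`: 42.6%
compound 3, `COc1ccc(C2=NOC(c3ccc(C)cc3)C2S(=O)(=O)CC2=NCCO2)cc1`: 65.9%

All three were tested in a functional assay, tested at 50 ug/mL; a higher number here means a stronger effect of the compound at the concentration tested, a lower number a weaker effect. Compound 1 and compound 2 share one core and differ in a single place: a group of 5 heavy atoms (3 carbon, 1 nitrogen, 1 sulfur; one five-membered non-aromatic ring with 2 hetero atoms) in place of a group of 5 heavy atoms (3 carbon, 1 nitrogen, 1 oxygen; one five-membered non-aromatic ring with 2 hetero atoms), on a saturated chain carbon bound to a sulfonyl sulfur. That change gave a number 19.9 percentage points lower from compound 1 to compound 2 (beyond the scatter). Compound 3 carries a different core; how its core differs from that of compound 1 is not broken down here. In this assay compound 3 gives 65.9%, and compound 1 gives 62.5%, two numbers that lie within the scatter of each other.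

Compound 4, `COc1ccc(C2=NOC(c3ccc(C)cc3)C2S(=O)(=O)CC2=NCCS2)cc1`, has not yet been measured. It stands to compound 3 as compound 2 stands to compound 1: a group of 5 heavy atoms (3 carbon, 1 nitrogen, 1 sulfur; one five-membered non-aromatic ring with 2 hetero atoms) in place of a group of 5 heavy atoms (3 carbon, 1 nitrogen, 1 oxygen; one five-membered non-aromatic ring with 2 hetero atoms), on a saturated chain carbon bound to a sulfonyl sulfur. The place is the same in both pairs, so this is the same change seen once already. Among the compounds with values here, with only one earlier instance to go on, the step from compound 3 to compound 4 is expected to be of about the same size, a number 19.9 percentage points lower from compound 3 to compound 4 (beyond the scatter), because the same change gave a number 19.9 percentage points lower from compound 1 to compound 2 (beyond the scatter). Compound 4 is therefore expected to give about 46% in this assay, most likely between 32% and 60%.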

Compound 4, a percentage reported as activity, at one concentration (the size of the read-out at that concentration, not a potency): 47.5%
Beside the measured number, compound 4's estimate is 1.5 percentage points below it; the measured number falls inside the stated range.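

In this assay, the five-membered ring with sulfur in place of the five-membered ring with oxygen, on a saturated chain carbon bound to a sulfonyl sulfur, gave a number 18.4 percentage points lower from compound 3 to compound 4 (beyond the scatter). The change therefore carried over from one core to the other with about the same size: the same change on two cores in this assay, a number 19.9 percentage points lower (beyond the scatter) from compound 1 to compound 2 and a number 18.4 percentage points lower (beyond the scatter) from compound 3 to compound 4, 1.5 percentage points apart, within the scatter of two such steps. This shows that, for these two pairs, the effect of the change did not depend on which of the two cores carried it, but it does not show that the same would hold on a third core, at another concentration or in another assay, and it does not explain why the sulfur ring gives the lower number.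

The compounds shown leave open whether other groups at this place, such as an open-chain amine, a carboxylic acid or a six-membered ring with the same hetero atoms, would give numbers nearer those of the oxygen ring or of the sulfur ring. They also leave open whether the step keeps its size when the methoxy or methyl group on the outer benzene rings is replaced by a chlorine atom.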